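One group swapped at the assay limit

This account rests on a few compounds, and the source may have more. Where it says the series, first, only, none or still open, it means among the compounds named here.

Measured in a functional assay on BaF3 cells (Mus musculus) for inhibition, read by MTT assay, with a stated time of 3 days; on this read-out higher numbers stand for weaker inhibition of growth and lower numbers for stronger inhibition of growth:
- Compound 1 `Cc1cc(C)cc(NC(=O)Nc2ccc(Nc3ncnc4c3OCCN4)cc2)c1`: > 10000 nM (a limit)
- Compound 2 `O=C(Nc1ccc(Nc2ncnc3c2OCCN3)cc1)Nc1cc(Cl)cc(Cl)c1`: 10000 nM
- Compound 3 `O=C(Nc1ccc(Nc2ncnc3c2OCCN3)cc1)Nc1cccc2ccccc12`: > 10000 nM (a limit)

This small set is marked by the limit of > 10000 nM in this assay, at which 2 of the 3 values shown sit. For compound 3, > 10000 nM is a limit and not a number.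

Compound 4 `CC(C)(C)c1cc(NC(=O)Nc2ccc(Nc3ncnc4c3OCCN4)cc2)no1` differs from compound 3 in one place, on an amide-type nitrogen: 5-(tert-butyl)-1,2-oxazol-3-yl in place of naphthalen-1-yl on an amide-type nitrogen. Here 5-(tert-butyl)-1,2-oxazol-3-yl takes the place of naphthalen-1-yl.

The measured steps that bear on this change the same group: a number no higher from compound 1 to compound 2 (the limit leaves the size open), a step that the two limits leave unreadable from compound 1 to compound 3 and a number no lower from compound 2 to compound 3 (the limit leaves the size open). The limits leave the size of all of them open, so they offer no measured size to carry over.

Only a small step towards stronger inhibition of growth is expected, if any. Within the data shown here, compound 2 at 10000 nM is the only number in the set. The expected change is an at least 1.2-fold lower number from compound 3 to compound 4 (0.09 log units; that floor lies within the scatter). The assay may well report only a limit again. For compound 4 the estimate is 8000 nM, with an expected range from 1500 nM to 15000 nM.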

Compound 4, concentration for 50% growth inhibition: > 10000 nM
Compound 4 ended at the assay's limit (the forecaster's own chance of this, stated with the estimate: 60%); middle value at least 1.2-fold (0.09 log units) from the limit.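

In this assay compound 4 gives > 10000 nM, which is a limit and not a number. Measured against compound 2, the swap to 5-(tert-butyl)-1,2-oxazol-3-yl gives a number no lower from compound 2 to compound 4 (the limit leaves the size open), so a five-membered aromatic ring with 2 hetero atoms on the amide-type nitrogen brings no readable gain, and of the four groups shown only 3,5-dichlorophenyl gives a number. The steps from compound 1 and from compound 3 to compound 4 join limit to limit and cannot be read, and the set remains defined by one feature: the limit of > 10000 nM in this assay, at which 3 of the 4 values shown sit.

The compounds shown do not tell whether any group at this position can give clear inhibition of growth. Nor do they tell how a pyridin-3-yl ring or a chain ending in an amine would behave there.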